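Chloro on the fused ring of a sulfonyl pyridazinone

The source may hold more compounds than are shown below. What is called first, only, known or untested is meant among the compounds shown, and "the series" means these compounds.

Measured so far:
compound 1, `O=S(=O)(c1ccccc1)c1ccc(O)nn1`: 14%
compound 2, `O=c1ccc(S(=O)(=O)c2cc3cc(Cl)ccc3o2)n[nH]1`: 39%
compound 3, `Cc1c(S(=O)(=O)c2ccc(O)nn2)oc2ccccc12`: 43%

In a functional assay on the whole organism for inhibition, with Rattus norvegicus as the target, with a stated time of 60 min, at pH 4.5, at a dose of 10 mg/kg by the oral route (on this read-out higher numbers stand for a stronger effect at the one dose given and lower numbers for a weaker effect), compound 3 gives 43%. Compound 1, with 14%, lies beyond the scatter below compound 3, whereas compound 2, with 39%, sits within the scatter of compound 3. Compound 4, `Cc1c(S(=O)(=O)c2ccc(O)nn2)oc2cc(Cl)ccc12`, differs from compound 3 by chloro in place of hydrogen on an aromatic carbon. No step between two measured compounds shows this change alone, so the step from compound 3 to compound 4 cannot be read from the numbers shown. Because compound 2 carries a chloro on its fused ring and gives 39%, compound 4 is expected to stay near compound 3, with a number 2 percentage points higher from compound 3 to compound 4 (within the scatter) expected to fall within the scatter. Compound 4 is thus estimated at 45%, within 30% to 60%.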

Compound 4, a percentage reported as inhibition, in the whole organism at one dose (the size of the read-out at that dose, not a potency): 28%
Compound 4: the middle estimate sits 17 percentage points above what was measured; the measured number lies below the stated range.
By their numbers in this assay, from the lowest: compound 1; then compound 4; then compounds 2 and 3 (each within the scatter of the next).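

With chloro in place of hydrogen on an aromatic carbon of the six-membered ring, this assay gives a number 15 percentage points lower from compound 3 to compound 4 (beyond the scatter). For the compounds shown here, this is the first single change that can be read, since no earlier pair differed in one place, and it shows that chloro at this position lowers the effect. No measurement given here accounts for the loss.

The compounds shown leave open whether chloro on another carbon of this ring would also lower the effect. They also leave open how fluoro, methoxy or an amine would fare at this position.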